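Swapping the Methoxy for a Hydroxyl on the Saturated Ring

A few compounds are considered here, and "the series" means these few. Any claim that something is new, unique, unknown or untested is made for them only; others in the source may bear on it.

Compound 1 `CO[C@H]1CC[C@@H](Nc2cc(NCc3cnccc3C(F)(F)F)ncc2C#N)CC1` is measured in an assay on isolated protein for inhibition of protein kinase C delta type (Homo sapiens), read by TR-FRET, with a stated time of 2 h (a higher number here means a weaker inhibitor, a lower number a stronger inhibitor), where compound 1 gives 5000 nM, the highest of the two numbers recorded so far. Within the data shown here, the only comparator is compound 2 `N#Cc1cnc(NCc2cnccc2C(F)(F)F)cc1N[C@H]1CC[C@@H](c2nc[nH]n2)CC1`, which in this assay gives 1200 nM; the change that leads there is a 1H-1,2,4-triazol-3-yl in place of methoxy on a saturated ring carbon, and it yields a 4.2-fold lower number from compound 1 to compound 2 (0.62 log units; beyond the scatter).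

Compound 3 `CC1(C)C[C@H](Nc2cc(NCc3cnccc3C(F)(F)F)ncc2C#N)CC[C@@H]1O` changes the same saturated ring in a different way: 4-hydroxy-3,3-dimethylcyclohexyl in place of 4-methoxycyclohexyl on a nitrogen on an aromatic ring. Among the measured compounds shown here, no measured step covers this exact exchange, so the one step from compound 1 to compound 2 is the only guide; it shows that altering that ring substituent can move the number modestly. On that basis compound 3 is expected to show a 1.7-fold lower number from compound 1 to compound 3 (0.22 log units; within the scatter), most likely a small gain. Compound 3 is thus estimated at 3000 nM, with a plausible range from 1000 nM to 10000 nM.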

Compound 3, half-maximal inhibitory concentration: 500 nM
Compound 3: the middle estimate sits 6.0-fold (0.78 log units) above what was measured; measured number below the stated range.
By their numbers in this assay, from the lowest: compound 3; then compound 2; then compound 1.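

The group on this nitrogen can shift the number further than the earlier pair revealed: in this assay, 4-hydroxy-3,3-dimethylcyclohexyl in place of 4-methoxycyclohexyl gives a 10-fold lower number from compound 1 to compound 3 (1.00 log units; beyond the scatter). This step keeps the six-membered carbon ring and adds no 1H-1,2,4-triazol-3-yl group, yet the entering group differs in two ways at once, with a hydroxyl in place of the methoxy and two added methyl groups. No measurement at hand explains the gain.

The compounds shown do not separate the contribution of the hydroxyl from that of the methyl groups, which a plain 4-hydroxycyclohexyl group would help to address. As far as these compounds go, it also remains open how an amine or a carboxylic acid at that ring carbon would compare.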